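The compounds below may be only part of what the source reports. "The series", "measured", "known", "first", "only" and "open" are said of these compounds alone.

Of the compounds shown here, three built on one shared core have been tested in a functional assay on NALM-6 cells (Homo sapiens) for cytotoxicity, with a stated time of 72 h (a higher number here means that more compound is needed for the effect, a lower number that less compound is needed), and none of them gives a number. Compound 1 `C=C[C@@](C)(/C=C/c1ccc(OC)cc1)CCC=C(C)C`, with methoxy on the aromatic ring, returns only a limit of > 43400 nM. Compound 2 `C=C[C@@](C)(/C=C/c1ccc(OCc2ccccc2)cc1)CCC=C(C)C`, with benzyloxy in that place, also returns only a limit of > 43400 nM. Compound 3 `C=C[C@@](C)(/C=C/c1ccc(Nc2cc(F)cc(F)c2)cc1)CCC=C(C)C`, with (3,5-difluorophenyl)amino there, likewise stands at a limit of > 43400 nM.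

Compound 4 `C=C[C@@](C)(/C=C/c1ccc(-c2ccc(F)cc2)cc1)CCC=C(C)C` carries 4-fluorophenyl in place of (3,5-difluorophenyl)amino on an aromatic carbon, (4-fluorophenyl in place of (3,5-difluorophenyl)amino on an aromatic carbon). Two measured changes at this aromatic carbon bear on the question: a step that the two limits leave unreadable from compound 1 to compound 3 and a step that the two limits leave unreadable from compound 2 to compound 3. The remaining measured change, a step that the two limits leave unreadable from compound 1 to compound 2, gives no size either. With no readable size to carry over, no step beyond the scatter can be expected in this assay because of the limit of > 43400 nM in this assay, at which 3 of the 3 values shown sit. For the measured compounds named here, a real gain for compound 4 cannot be excluded, but the compounds tested so far offer no sign of one. The estimated step is a step that the limit leaves unreadable from compound 3 to compound 4, and a further report of a limit is the likeliest result. The estimate for compound 4 is 50000 nM, with an expected range from 20000 nM to 100000 nM.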

Compound 4, half-maximal effective concentration: > 43400 nM
Compound 4 gave a limit, no number; the forecaster's own chance of this, stated with the estimate: 75%; the middle value lies beyond the limit too.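

In this assay, for the compounds shown here, compound 4 returns only a limit, as do compound 1, compound 2 and compound 3, so no step from any of those three to compound 4 can be read: the limit of > 43400 nM in this assay, at which 4 of the 4 values shown sit. The compounds shown leave open what number any of the four would give, and whether any group at this aromatic carbon would bring a readable value.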